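Cyanoacrylamide series on A-431 growth: pyrrole to chlorophenyl

A few compounds are considered here, and "the series" means these few. Any claim that something is new, unique, unknown or untested is made for them only; others in the source may bear on it.

Measured so far in a functional assay on A-431 cells (Homo sapiens) for inhibition, read by MTT assay, with a stated time of 72 h; a lower number here means a stronger inhibitor of growth, a higher number a weaker inhibitor of growth:
compound 1 `N#C/C(=C\c1c[nH]c2ccccc12)C(=O)c1c[nH]c2ccccc12` gives 7600 nM
compound 2 `COc1ccc(CNC(=O)/C(C#N)=C/c2ccc[nH]2)cc1` gives only a limit, > 50000 nM
compound 3 `N#C/C(=C\c1ccco1)C(=O)NCc1ccc(Cl)c(Cl)c1` gives only a limit, > 50000 nM

Compound 2 stands at the limit of > 50000 nM in this assay, at which 2 of the 3 values shown sit; this is a limit of the assay, not a number, so only an upper bound on its potency is known. Among the compounds with values here, compound 1 is the sole member with a numerical value. Within the data shown here, no two measured compounds differ in a single place, so no measured step is available for reading direction or size.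

The next compound, compound 4 `COc1ccc(CNC(=O)/C(C#N)=C/c2ccc(Cl)cc2)cc1`, differs from compound 2 by 4-chlorophenyl in place of 1H-pyrrol-2-yl on a double-bonded chain carbon bound to a double-bonded chain carbon, in words: 4-chlorophenyl in place of 1H-pyrrol-2-yl on a double-bonded chain carbon bound to a double-bonded chain carbon. Compound 3 carries a different five-membered ring at that position and also sits at the limit; nothing measured here tells how a six-membered carbon ring behaves there.

Starting from a limit, the expected step from compound 2 to compound 4 is an at least 1.4-fold lower number from compound 2 to compound 4 (0.15 log units; that floor lies within the scatter), and it may not register as a number at all. Compound 4 is estimated at 35000 nM, with a range of 10000 nM to 100000 nM.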

Compound 4, concentration for 50% growth inhibition: 6000 nM
Compound 4: middle estimate off by 5.8-fold (0.77 log units), on the high side; the measured number lies below the stated range.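

Replacing 1H-pyrrol-2-yl with 4-chlorophenyl on a double-bonded chain carbon bound to a double-bonded chain carbon shows that this position can move growth inhibition in this assay: the change gives an at least 8.3-fold lower number from compound 2 to compound 4 (0.92 log units; beyond the scatter). Among the amides shown, compound 4 is the only one with a numerical value, 6000 nM, so a six-membered aromatic ring of carbon at this position gives the series a measurable number in this one pair. The true size of the step remains unknown and only its floor is printed, because compound 2 has a limit and not a number: the limit of > 50000 nM in this assay, at which 2 of the 4 values shown sit.

Within the data shown here, the single pair does not separate the contribution of the chlorine from that of the six-membered aromatic ring itself, and a plain phenyl or a 4-aminophenyl at the same position would address that question. As far as these compounds go, compound 3 differs from compound 4 in more than one place, so the furan-bearing compound gives no clean reading of ring choice at this position, and whether the gain carries over to other amide substituents remains open.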